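The source may hold more compounds than are shown below. What is called first, only, known or untested is meant among the compounds shown, and "the series" means these compounds.

Of the compounds shown here, three sharing one core have been tested in a functional assay on a cell-free system (plasma, Homo sapiens), with a stated time of 3 min; a higher number here means a weaker inhibitor, a lower number a stronger inhibitor. Compound 1 `CC(C)(C)C[C@@H](O)C(=O)N1[C@@H]2C[C@@H]2C[C@H]1C(=O)NCc1cc(Cl)ccc1-n1cnnn1` gives 520 nM, compound 3 `CCCC[C@@H](O)C(=O)N1[C@@H]2C[C@@H]2C[C@H]1C(=O)NCc1cc(Cl)ccc1-n1cnnn1` gives 870 nM, and compound 2 `O=C(NCc1cc(Cl)ccc1-n1cnnn1)[C@@H]1[C@H]2C[C@H]2CN1C(=O)[C@H](O)Cc1ccccc1` gives 1200 nM, the highest of the three numbers. Among the measured compounds shown here, the one step within this set, a 1.7-fold higher number from compound 1 to compound 3 (0.22 log units; within the scatter), stayed within the scatter. Compound 4 `CC(C)(C)OC[C@@H](O)C(=O)N1C[C@@H]2C[C@@H]2[C@H]1C(=O)NCc1cc(Cl)ccc1-n1cnnn1` differs from compound 2 by tert-butoxy in place of phenyl on a saturated chain carbon, two bonds along the chain from a carbonyl carbon and an oxygen on a saturated carbon. For the measured compounds named here, no measured step covers a change of this kind, so the expectation rests on the spread among compounds 1, 2 and 3, which differ only in this side chain. For compound 4 in this assay a move toward the lower numbers of the set is expected, a 1.7-fold lower number from compound 2 to compound 4 (0.23 log units; within the scatter), with the estimate at 700 nM and a range from 300 nM to 1800 nM. Such a number would place compound 4 nearer to compounds 1 and 3 than to compound 2.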

Compound 4, half-maximal inhibitory concentration: 570 nM
Beside the measured number, compound 4's estimate is 1.2-fold (0.09 log units) above it; low and high end bracket the measured number.
By their numbers in this assay, from the lowest: compounds 1, 4, 3 and 2 (each within the scatter of the next, the first and the last beyond it).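

In this assay the change gives a 2.1-fold lower number from compound 2 to compound 4 (0.32 log units; beyond the scatter), a modest step and the only one at this position that lies beyond the scatter. At this place, then, an aromatic ring is not needed: tert-butoxy, with no ring and one hydrogen-bond acceptor, replaces phenyl with no loss, whereas swapping tert-butyl for propyl had shown no step beyond the scatter. Nothing available explains this step. Ring and oxygen change together here, so the compounds shown do not separate the two. A cyclohexyl group at this place, keeping a ring without aromaticity, would bear on that.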